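Cytotoxicity notes: from compound 2 to compound 4

The source may hold more compounds than are shown below. What is called first, only, known or untested is meant among the compounds shown, and "the series" means these compounds.

Measured set in an ADME assay on HCT-116 cells (Homo sapiens) for cytotoxicity, read by CellTiter-Glo, with a stated time of 72 h; a higher number here means a weaker inhibitor, a lower number a stronger inhibitor:
Compound 1 `COc1cc(C)ccc1S(=O)(=O)N1CCC(N2CCC(C)CC2)CC1` gives > 5000 nM, a limit of the assay.
Compound 2 `CC1CCN(C2CCN(S(=O)(=O)c3cccc(-c4ccccc4F)c3)CC2)CC1` gives > 5000 nM, a limit of the assay.
Compound 3 `CC1CCN(C2CCN(S(=O)(=O)c3ccc(Cl)c(C(F)(F)F)c3)CC2)CC1` gives > 5000 nM, a limit of the assay.

Compound 2 stands only at the limit of this assay, as do the other two members. The shared point is the limit of > 5000 nM in this assay, at which 3 of the 3 values shown sit. For the measured compounds named here, no step between measured compounds is available, so the numbers say nothing yet about any single change. Compound 4 `CC1CCN(C2CCN(S(=O)(=O)c3cccc(-c4ccccc4)c3)CC2)CC1` differs from compound 2 by hydrogen in place of fluoro on an aromatic carbon. For this change no step beyond the scatter is expected in this assay, in either direction, so the step that the limit leaves unreadable from compound 2 to compound 4 is estimated to stay within the scatter. Compound 4 is expected at 10000 nM (range 5000 nM to 40000 nM), most likely reported again only as a limit.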

Compound 4, half-maximal inhibitory concentration: > 5000 nM
Compound 4 was reported as a limit (the forecaster's own chance of this, stated with the estimate: 85%); the middle value does not contradict the limit.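

The step from compound 2 to compound 4 cannot be read in this assay, since both values are limits: the limit of > 5000 nM in this assay, at which 4 of the 4 values shown sit.

The compounds shown leave open whether any member of this series gives a measurable value in this assay.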